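A few compounds are considered here, and "the series" means these few. Any claim that something is new, unique, unknown or untested is made for them only; others in the source may bear on it.

Compound 1 `N#Cc1c(-c2nnc(-c3nn(-c4ccccc4)c(-c4ccccc4)c3C#N)c3nn(-c4ccccc4)cc23)nn(-c2ccccc2)c1-c1ccccc1` sits at a limit of a functional assay on MDA-N cells (Homo sapiens) for inhibition, read by sulforhodamine B assay, with a stated time of 48 h (on this read-out lower numbers stand for stronger inhibition of growth and higher numbers for weaker inhibition of growth), > 100000 nM, that is the limit of > 100000 nM in this assay, at which 1 of the 3 values shown sits. Compound 2 `N#Cc1c(-c2nnc(-c3nn(-c4ccccc4)c(-c4ccccc4)c3C#N)c3nn(-c4ccc(Cl)cc4)cc23)nn(-c2ccccc2)c1-c1ccccc1` gives 2260 nM in this assay. The step of an at least 44-fold lower number from compound 1 to compound 2 (1.64 log units; beyond the scatter) goes with chloro in place of hydrogen on an aromatic carbon. Compound 3 `N#Cc1c(-c2nnc(-c3ccccc3)c3nn(-c4ccccc4)cc23)nn(-c2ccccc2)c1-c1ccccc1` gives 31200 nM in this assay; the difference between the core of compound 3 and the core of compound 1 is not broken down here. Compound 4 `N#Cc1c(-c2nnc(-c3ccccc3)c3nn(-c4ccc(Cl)cc4)cc23)nn(-c2ccccc2)c1-c1ccccc1` carries the same change on the core of compound 3, (chloro in place of hydrogen on an aromatic carbon), at a place described in the same words as for compound 2. The earlier step begins at a limit, and its full size is not known. A step of a 31-fold lower number from compound 3 to compound 4 (1.49 log units; beyond the scatter) is expected, resting on an at least 44-fold lower number from compound 1 to compound 2 (1.64 log units; beyond the scatter). Compound 4 is therefore estimated at 1000 nM in this assay, with a range from 150 nM to 8000 nM.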

Compound 4, concentration for 50% growth inhibition: 63800 nM
For compound 4 the middle estimate is 64-fold (1.80 log units) below the measured one, and the stated range ends below it.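

In this assay, phenyl to 4-chlorophenyl gives a 2.0-fold higher number from compound 3 to compound 4 (0.31 log units; beyond the scatter). The change therefore does not carry from one core to the other in this series, in either direction or size: the same change on two cores in this assay, an at least 44-fold lower number (1.64 log units; beyond the scatter) from compound 1 to compound 2 and a 2.0-fold higher number (0.31 log units; beyond the scatter) from compound 3 to compound 4, at least 90-fold (1.95 log units) apart, beyond the scatter of two such steps

What this shows is a difference between two cores, not its cause and not the full size of the earlier step, whose starting point, compound 1, is a limit: the limit of > 100000 nM in this assay, at which 1 of the 4 values shown sits.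

Going by these compounds, it remains open whether the difference between the cores is specific to chloro or also holds for other groups at the same place, such as a methoxy group, an amine or a carboxylic acid. With only two cores shown, it also remains open which core behaviour other cores would follow.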